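Moving a methoxy group on the sulfonyl aryl ring

The source may report more compounds than this note shows. Statements on the series, on what has been measured and on what is new or still open speak of the compounds shown alone.

Compound 1: `COc1cc(N)c(Cl)cc1C(=O)CCC1CCN(CCNS(=O)(=O)c2ccc3c(c2)NC(=O)CO3)CC1`, 6.2 nM
Compound 2: `COc1ccc(S(=O)(=O)NCCN2CCC(CCC(=O)c3cc(Cl)c(N)cc3OC)CC2)cc1OC`, 8.2 nM

Of the compounds shown here, two have been measured in an assay on brain for displacement of a labelled ligand from 5-hydroxytryptamine receptor 4 (Cavia porcellus), with a stated time of 30 min, in the presence of a further agent that is not named here; a higher number here means a weaker inhibitor, a lower number a stronger inhibitor. Compound 1, with the bicyclic group on the sulfonyl sulfur, gives 6.2 nM. Compound 2 carries a 3,4-dimethoxyphenyl on that sulfur instead and gives 8.2 nM, the higher of the two numbers, though the step of a 1.3-fold higher number from compound 1 to compound 2 (0.12 log units; within the scatter) lies within the scatter, so the two values cannot be told apart.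

Compound 3, `COc1ccc(S(=O)(=O)NCCN2CCC(CCC(=O)c3cc(Cl)c(N)cc3OC)CC2)c(OC)c1`, has the same atoms as compound 2 joined differently: 2,4-dimethoxyphenyl in place of 3,4-dimethoxyphenyl on a sulfonyl sulfur. Going by the values given here, only one measured step bears on this place, the one from compound 1 to compound 2, and it was within the scatter despite exchanging a whole bicyclic group for a dimethoxyphenyl. The present change is smaller in kind, a shift of one methoxy group within the same ring. Among the compounds with values here, no measured pair shows what such a shift does in this assay, so the expectation is for a step of little size, a 1.5-fold higher number from compound 2 to compound 3 (0.17 log units; within the scatter), with a wide range to allow for either direction. Compound 3 is thus estimated at 12 nM in this assay, with a range from 4 nM to 40 nM.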

Compound 3, inhibition constant: 18.7 nM
For compound 3 the middle estimate is 1.6-fold (0.19 log units) below the measured one; low and high end bracket the measured number.
By their numbers in this assay, from the lowest: compounds 1 and 2 (each within the scatter of the next); then compound 3.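

In this assay, the arrangement of the methoxy groups on the ring at the sulfonyl sulfur now gives a readable difference: 2,4-dimethoxyphenyl in place of 3,4-dimethoxyphenyl, with the same atoms joined differently, gives a 2.3-fold higher number from compound 2 to compound 3 (0.36 log units; beyond the scatter), a modest step. The earlier exchange of the bicyclic group for 3,4-dimethoxyphenyl stayed within the scatter, whereas its exchange for 2,4-dimethoxyphenyl gives a 3.0-fold higher number from compound 1 to compound 3 (0.48 log units; beyond the scatter), also modest, so among these three compounds the outcome at this place depends on how the two methoxy groups are arranged and not merely on the presence of a dimethoxyphenyl. Nothing available here bears on the reason for these steps.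

The compounds shown leave open which of the two methoxy groups accounts for the difference, since each ring carries both; a ring with a single methoxy group, or with an ethoxy group or a chlorine in place of one methoxy group, would bear on this. They also leave open whether the same shift would give a similar step with a longer chain between the sulfonamide nitrogen and the rest of the shared core.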